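The source may hold more compounds than are shown below. What is called first, only, known or untested is meant among the compounds shown, and "the series" means these compounds.

Measured in a functional assay on HL-60 cells (Homo sapiens) for cytotoxicity, read by CCK-8 assay, with a stated time of 72 h; on this read-out higher numbers stand for weaker inhibition and lower numbers for stronger inhibition:

compound 1 `C=CCn1c(=O)/c(=C\c2ccc(F)c(Br)c2)[nH]c(=O)/c1=C\c1ccccc1OC`: "not active" (no number reported)
compound 2 `C=CCn1c(=O)/c(=C\c2cc(OC)c(OC)c(OC)c2)[nH]c(=O)/c1=C\c1cccc(Br)c1`: "not active" (no number reported)
compound 3 `COc1ccccc1/C=c1/[nH]c(=O)/c(=C\c2nc[nH]c2C(C)(C)C)[nH]c1=O`: 70 nM

Compound 1 has no single number in this assay: it is reported as inactive, as is compound 2, which shares its core, while compound 3, built on a different core, gives 70 nM. Compound 4 `C=CCn1c(=O)/c(=C\c2cccc(Cl)c2Cl)[nH]c(=O)/c1=C\c1ccccc1OC` keeps the core of compound 1 and differs from it only in one aromatic group: 2,3-dichlorophenyl in place of 3-bromo-4-fluorophenyl on a double-bonded chain carbon bound to an aromatic carbon. Within the data shown here, no measured step between compounds carrying this core is available, so the size of this step in this assay cannot be read from the data. Compound 4 is expected to stay weak, in line with compound 1 and compound 2, with a good chance that again only an inactive result is reported. The estimate for compound 4 is 20000 nM, within 3000 nM to 100000 nM.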

Compound 4, half-maximal inhibitory concentration: 2000 nM
Beside the measured number, compound 4's estimate is 10-fold (1.00 log units) above it; measured number below the stated range.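

Among these compounds, compound 1 has no single number, so no step to compound 4 can be read. What the 2,3-dichlorophenyl group contributes to the activity of compound 4 stays open, and no available measurement offers an explanation.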